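A few compounds are considered here, and "the series" means these few. Any claim that something is new, unique, unknown or untested is made for them only; others in the source may bear on it.

Going by the values given here, compound 1 `COc1ccc(-c2cc3nccc(-c4cc(OC)c(OC)c(OC)c4)n3n2)cc1N` gives 251 nM in a functional assay on HCT-116 cells (Homo sapiens) for inhibition, read by CCK-8 assay, with a stated time of 48 h (on this read-out lower numbers stand for stronger inhibition and higher numbers for weaker inhibition), the lower of the two numbers known so far. Compound 2 `COc1cc(-c2ccnc3cc(-c4ccc(Cl)cc4)nn23)cc(OC)c1OC` gives 3340 nM, and the change that separates them produced a 13-fold higher number from compound 1 to compound 2 (1.12 log units; beyond the scatter). Compound 3 `COc1cc(-c2ccnc3cc(-c4ccc(C(C)=O)cc4)nn23)cc(OC)c1OC` differs from compound 1 at the same position: 4-acetylphenyl in place of 3-amino-4-methoxyphenyl on an aromatic carbon. Since that one measured step, in which the same group left, weakened inhibition markedly, a comparable weakening is expected here as well, namely an 8.8-fold higher number from compound 1 to compound 3 (0.94 log units; beyond the scatter). Compound 3 is therefore estimated to give 2200 nM, with a likely range from 700 nM to 7000 nM.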

Compound 3, half-maximal inhibitory concentration: 4390 nM
Beside the measured number, compound 3's estimate is 2.0-fold (0.30 log units) below it; low and high end bracket the measured number.
By their numbers in this assay, from the lowest: compound 1; then compounds 2 and 3 (each within the scatter of the next).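

In this assay, 4-acetylphenyl in place of 3-amino-4-methoxyphenyl also weakens inhibition at this position (a 17-fold higher number from compound 1 to compound 3 (1.24 log units; beyond the scatter)), so the loss is not confined to the 4-chlorophenyl replacement. The two replacements cannot be told apart, as acetyl in place of chloro stays within the scatter (a 1.3-fold higher number from compound 2 to compound 3 (0.12 log units; within the scatter)). No available evidence accounts for these results. Going by these compounds, it remains open whether the amine or the methoxy group of 3-amino-4-methoxyphenyl accounts for the gap, and what a hydroxyl or an amide in place of that amine would give.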